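Indole Amide on a Shared Azabicyclic Core at the Nicotinic Receptor

The source may report more compounds than this note shows. Statements on the series, on what has been measured and on what is new or still open speak of the compounds shown alone.

Compound 1 `O=C(Nc1cccc(Br)c1)N[C@@H]1C2CCN(CC2)[C@@H]1Cc1cccnc1`: in an assay on a protein complex for binding affinity to Neuronal acetylcholine receptor; alpha4/beta2 (Homo sapiens) (a lower number here means a stronger inhibitor, a higher number a weaker inhibitor), compound 1 gives > 10000 nM, a limit of the assay.
Compound 2 `Cn1cccc1C(=O)N[C@@H]1C2CCN(CC2)[C@@H]1Cc1cccnc1`: in this assay compound 2 gives > 10000 nM, also a limit.

Compound 2 therefore stands at the limit of this assay; no number is known for it. Among the compounds with values here, the one measured step, a step that the two limits leave unreadable from compound 1 to compound 2, cannot be read, as both ends sit at the limit (the limit of > 10000 nM in this assay, at which 2 of the 2 values shown sit). Compound 3 `O=C(N[C@@H]1C2CCN(CC2)[C@@H]1Cc1cccnc1)c1c[nH]c2ccccc12` carries the change (1H-indol-3-yl in place of 1-methyl-1H-pyrrol-2-yl on a carbonyl carbon). Within the data shown here, no measured step bears on this change, and the two measured values give only a limit each. With compound 2 at > 10000 nM as its starting point, compound 3 is expected to remain weak. The expected step is a step that the limit leaves unreadable from compound 2 to compound 3, not readable beyond the scatter. Compound 3 is estimated at 15000 nM in this assay, within a range from 3000 nM to 60000 nM.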

Compound 3, inhibition constant: > 10000 nM
Compound 3: a limit, no number; the forecaster's own chance of this, stated with the estimate: 75%; the middle value is on the limit's open side.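

In this assay compound 3 gives > 10000 nM, a limit and not a number, so neither step to compound 3, from compound 1 or from compound 2, can be read: the limit of > 10000 nM in this assay, at which 3 of the 3 values shown sit. The compounds shown leave open how far each one's true affinity lies beyond that limit.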